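Methoxy to hydrogen on the 2,4-dimethoxybenzyl group

The source may report more compounds than this note shows. Statements on the series, on what has been measured and on what is new or still open speak of the compounds shown alone.

Compound 1 `COc1ccc(Cn2c(CCc3c[nH]c4ccccc34)nnc2[C@H](NC(=O)c2ccccn2)c2c[nH]c3ccccc23)c(OC)c1` is the reference point of this small set. In a functional assay on CHO cells for antagonist activity at growth hormone secretagogue receptor type 1 (Homo sapiens) (on this read-out higher numbers stand for weaker inhibition and lower numbers for stronger inhibition), compound 1 gives 19 nM. Compound 2 `COc1ccc(Cn2c(CCc3c[nH]c4ccccc34)nnc2[C@H](NC(=O)c2ccccn2)c2c[nH]c3ccccc23)cc1` carries the change hydrogen in place of methoxy on an aromatic carbon on the same core. In this assay, for the measured compounds named here, compound 2 gives 102 nM, and the step of a 5.4-fold higher number from compound 1 to compound 2 (0.73 log units; beyond the scatter) is the only measured instance of this change so far.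

Compound 3 `COc1ccc(Cn2c(CCc3ccccc3)nnc2[C@H](NC(=O)c2cnccn2)c2c[nH]c3ccccc23)c(OC)c1` sits on a different core, and the difference between the two cores is not broken down here. In this assay compound 3 gives 24 nM, a number within the scatter of that of compound 1, while the gap to compound 2 lies beyond the scatter, compound 2 being the higher of the two.

Compound 4 `COc1ccc(Cn2c(CCc3ccccc3)nnc2[C@H](NC(=O)c2cnccn2)c2c[nH]c3ccccc23)cc1` differs from compound 3 by hydrogen in place of methoxy on an aromatic carbon. The place of this change is described in the same words as the place of the change from compound 1 to compound 2, so it is the same change, now made on the core of compound 3. Compound 4 is therefore expected to move by a 5.4-fold higher number from compound 3 to compound 4 (0.73 log units; beyond the scatter). Going by the values given here, that expectation rests on compound 1 and compound 2, whose step a 5.4-fold higher number from compound 1 to compound 2 (0.73 log units; beyond the scatter) is the single measured example of the change and lies beyond the scatter. Among the compounds with values here, compound 4 is estimated at 130 nM, with a likely range from 50 nM to 350 nM, kept wide since only one earlier instance exists.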

Compound 4, antagonist equilibrium constant: 530 nM
For compound 4 the middle estimate is 4.1-fold (0.61 log units) below the measured one, and the stated range ends below it.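

Going from the 2,4-dimethoxybenzyl group to the 4-methoxybenzyl group raises the number again on the second core in this assay, with a 22-fold higher number from compound 3 to compound 4 (1.34 log units; beyond the scatter), so the direction of the change carries over in both available pairs. The size of the change does not carry over, and a step taken from one core cannot be applied unchanged to the other: the same change on two cores in this assay, a 5.4-fold higher number (0.73 log units; beyond the scatter) from compound 1 to compound 2 and a 22-fold higher number (1.34 log units; beyond the scatter) from compound 3 to compound 4, 4.1-fold (0.61 log units) apart, beyond the scatter of two such steps

These two pairs do not show which feature of the cores sets the size of the step, since the core of compound 1 and the core of compound 3 are separated by a difference that is not broken down here, and two instances give no rule for any further core.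

Still open, from the compounds shown here alone, is whether a smaller or different group, such as a fluorine, a chlorine, a hydroxyl or an ethoxy, would hold the number near that of the methoxy compounds if placed ortho to the large group. Also open, going by these compounds, is how large the step would be on a core that carries only part of the difference between the core of compound 1 and the core of compound 3, and what replacing the remaining methoxy would do on either core.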